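A Larger Ester Chain on the Amide of Compound 1

The compounds below may be only part of what the source reports. "The series", "measured", "known", "first", "only" and "open" are said of these compounds alone.

The account covers three measured compounds and one that is still to be measured. Compound 1 `C[C@H](NC(=O)CN(c1nc(Cl)nc2[nH]cnc12)C1CC1)C(=O)OCc1ccccc1` gives 41.2% in a functional assay on the whole organism (Tail, strain ICR) with Mus musculus as the target, in the tail flick test, with a stated time of 30 min, at a dose of 25 umol/kg by the oral route; on this read-out higher numbers stand for a stronger effect at the one dose given and lower numbers for a weaker effect. Compound 2 `O=C(O)[C@@H]1CCCN1C(=O)CN(c1nc(Cl)nc2[nH]cnc12)C1CC1` gives 31.5% in this assay, a number that lies within the usual scatter of the value of compound 1. Compound 3 `O=C(CN(c1ncnc2c1ncn2C1CCCCO1)C1CC1)NCC(=O)OCc1ccccc1` gives 55.7% in this assay, a number that stands beyond the scatter above compound 1. Among the three numbers, compound 1 therefore holds the second highest place, close to compound 2 and clearly below compound 3.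

Compound 4 `O=C(CN(c1nc(Cl)nc2[nH]cnc12)C1CC1)N[C@@H](CCC(=O)OCc1ccccc1)C(=O)OCc1ccccc1` differs from compound 1 by (benzyloxycarbonyl)methyl in place of hydrogen on a saturated chain carbon, two bonds along the chain from an amide-type nitrogen and a carbonyl carbon. Among the compounds with values here, no pair of measured compounds shows this change, so the data give no measured step for it. The two measured chain variants, compound 1 and compound 2, sit within the scatter of each other, and a comparable outcome is expected here. The step is expected to be a number 1.2 percentage points lower from compound 1 to compound 4 (within the scatter), none beyond the scatter in this assay. Compound 4 is estimated at 40%, within a range from 22% to 58%.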

Compound 4, a percentage reported as activity, at one dose (the size of the read-out at that dose, not a potency): 52.8%
Compound 4: middle estimate off by 12.8 percentage points, on the low side; measured number inside the range.
By their numbers in this assay, from the lowest: compounds 2 and 1 (each within the scatter of the next); then compounds 4 and 3 (each within the scatter of the next).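

Placing (benzyloxycarbonyl)methyl on a saturated chain carbon, two bonds along the chain from an amide-type nitrogen and a carbonyl carbon, gives a number 11.6 percentage points higher from compound 1 to compound 4 (beyond the scatter) in this assay. Within the data shown here, this is the first measured step at this position, and it shows that the position accepts this much larger group with no loss of effect at the one dose given, and with a higher number. Nothing measured here explains the rise.

From the compounds shown here alone, it remains open whether the step comes from the whole 2-(benzyloxycarbonyl)ethyl chain or only part of it, which a plain ethyl group in place of the methyl, or a carboxylic acid in place of the benzyl ester, would help to separate. Also open, going by these compounds, is whether a longer chain or a terminal amine at this position would give a similar number.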